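This account rests on a few compounds, and the source may have more. Where it says the series, first, only, none or still open, it means among the compounds named here.

Of the compounds shown here, two of a shared core have been measured in an assay on HEK293 cells for inhibition of Nitric oxide synthase, inducible (Homo sapiens), read by fluorescence; a lower number here means a stronger inhibitor, a higher number a weaker inhibitor. Compound 1 `O=c1cc(CN(c2cccnc2)c2cccc(Cl)c2)c2ccc(F)c(F)c2[nH]1` gives 77 nM in this assay. Compound 2 `O=c1cc(CN(Cc2ccccc2F)c2cnccn2)c2ccc(F)c(F)c2[nH]1` gives 12 nM in this assay. Of the two numbers, compound 1 stands highest: compound 2 gives the lower number, and the gap between the two lies beyond the usual scatter, so compound 1 is the weaker inhibitor of the pair. Compound 2 differs from compound 1 in more than one place, so its number says nothing about any single change.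

Compound 3 `COc1cc(N(Cc2cc(=O)[nH]c3c(F)c(F)ccc23)c2cccc(Cl)c2)ncn1` has not been measured. It differs from compound 1 in one place: 6-methoxypyrimidin-4-yl in place of pyridin-3-yl on a nitrogen on an aromatic ring. Among the compounds with values here, no measured pair shows this change, so no size of step is known for it; the step from compound 1 to compound 3 is expected to be a 1.3-fold lower number from compound 1 to compound 3 (0.11 log units; within the scatter), that is, no change beyond the scatter in either direction. Compound 3 is therefore estimated to give 60 nM, within a range from 20 nM to 200 nM.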

Compound 3, half-maximal inhibitory concentration: 61 nM
Beside the measured number, compound 3's estimate is 1.0-fold (0.01 log units) below it; low and high end bracket the measured number.
By their numbers in this assay, from the lowest: compound 2; then compounds 3 and 1 (each within the scatter of the next).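

In this assay, a 1.3-fold lower number from compound 1 to compound 3 (0.10 log units; within the scatter) when 6-methoxypyrimidin-4-yl replaces pyridin-3-yl on the nitrogen, so the two compounds cannot be told apart. Within the data shown here, this is the first measured change at this one place, and it shows that a larger ring, with an additional ring nitrogen and a methoxy group, can sit there without the number moving beyond the scatter. No supporting measurement bears on why the two groups read alike.

This single step cannot separate the part played by the methoxy group from that of the additional ring nitrogen, so the plain pyrimidin-4-yl group would be informative. It also leaves open what happens when an amine or a carboxylic acid takes the place of the methoxy group on this ring.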